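The source may report more compounds than this note shows. Statements on the series, on what has been measured and on what is new or still open speak of the compounds shown alone.

Series notes, cytotoxicity set. All three measured compounds were run in a functional assay on UO-31 cells (Homo sapiens) for cytotoxicity, read by sulforhodamine B assay, with a stated time of 48 h; a lower number here means a stronger inhibitor of growth, a higher number a weaker inhibitor of growth:

compound 1 `ClCc1cccc(Cn2cnc3c(Cl)ncnc32)c1` — 1440 nM
compound 2 `ClCc1cccc(Cn2cnc3c(Cl)nc(Cl)nc32)c1` — 1580 nM
compound 3 `ClCc1ccccc1Cn1cnc2ncnc(Cl)c21` — 3230 nM

Compound 1 and compound 2 share one core and differ in a single place: chloro in place of hydrogen on an aromatic carbon. That change gave a 1.1-fold higher number from compound 1 to compound 2 (0.04 log units; within the scatter), so the two numbers cannot be told apart.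

Compound 3 is built from the same atoms as compound 1, joined differently; the difference between the two cores is not broken down here. Its number in this assay is the highest of the three, and its distance from both compound 1 and compound 2 lies beyond the scatter, so compound 3 is the weakest inhibitor of growth among the measured compounds.

Compound 4 `ClCc1ccccc1Cn1cnc2nc(Cl)nc(Cl)c21` has not yet been measured. It stands to compound 3 as compound 2 stands to compound 1: chloro in place of hydrogen on an aromatic carbon. The place of the change is described in the same words for both pairs, so this is the same change, made for the second time in the set.

The expectation for compound 4 rests on a single precedent, the step of a 1.1-fold higher number from compound 1 to compound 2 (0.04 log units; within the scatter). On that basis the step from compound 3 to compound 4 in this assay is expected to be a 1.1-fold higher number from compound 3 to compound 4 (0.03 log units; within the scatter), that is, a number close to that of compound 3. Compound 4 is therefore estimated at 3500 nM, with the expected range from 1800 nM to 7000 nM.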

Compound 4, concentration for 50% growth inhibition: 1730 nM
Compound 4: the middle estimate sits 2.0-fold (0.31 log units) above what was measured; measured number below the stated range.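

In this assay chloro in place of hydrogen on an aromatic carbon gave a 1.9-fold lower number from compound 3 to compound 4 (0.27 log units; within the scatter) and so, as with compound 1 and compound 2, the two numbers of the pair cannot be told apart. Set side by side, the two steps give no sign that the core changes what this substitution does, and on these numbers the change carries from the core of compound 1 to the core of compound 3 without a difference that can be resolved: the same change on two cores in this assay, a 1.1-fold higher number (0.04 log units; within the scatter) from compound 1 to compound 2 and a 1.9-fold lower number (0.27 log units; within the scatter) from compound 3 to compound 4, 2.0-fold (0.31 log units) apart, within the scatter of two such steps. This rests on two pairs only, each with a step inside the scatter, so it does not show that the two steps run in truly opposite directions, that they are truly equal, or that the same would hold on any further core.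

Open, going by these compounds, is how an amine, a methoxy group or a longer chain would compare with chloro on the aromatic carbon between two ring nitrogen atoms, on either core. Equally open, on these data alone, is what a hydroxymethyl or a methyl group in place of the chloromethyl group would do to the numbers in this assay on these cores.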